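Amide nitrogen substituent variation in an alkyne-linked modulator series

The source may hold more compounds than are shown below. What is called first, only, known or untested is meant among the compounds shown, and "the series" means these compounds.

Compound 1 `C[C@@H](NC(=O)c1ccc(C#Cc2ccc(F)cc2)cn1)C(C)(C)O` and compound 2 `C[C@@H](NC(=O)c1ccc(C#Cc2cccc(F)c2)cn1)C(C)(C)C` share the same core and differ only in the group on the amide nitrogen. In a functional assay on HEK293 cells for positive allosteric modulation of metabotropic glutamate receptor 5 (Rattus norvegicus), read by fluorescence and calcium flux (a higher number here means a larger maximal response, a lower number a smaller maximal response), compound 1 gives 66.2%, and in the same assay compound 2 gives 66%. Compound 2 lies within the scatter of compound 1 , so the two numbers are read as the same; no ranking between them is supported.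

Compound 3 `CC(C)CNC(=O)c1ccc(C#Cc2cccc(F)c2)cn1` carries isobutyl in place of 1,2,2-trimethylpropyl on an amide-type nitrogen. Within the data shown here, no measured pair covers a change of this kind on the amide nitrogen, so the size and direction of the step rest on expectation alone. The step of a number 6 percentage points lower from compound 2 to compound 3 (within the scatter) is expected to be a modest decrease that may still fall within the scatter. For compound 3 the expected value in this assay is 60%, with a range from 40% to 80%.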

Compound 3, largest response reached (reported as efficacy), in percent of the reference or control that the assay uses: 58.2%
Compound 3: middle estimate off by 1.8 percentage points, on the high side; the measured number falls inside the stated range.
By their numbers in this assay, from the lowest: compounds 3, 2 and 1 (each within the scatter of the next).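

Among these compounds, this is the first pair that differs only in the group on the amide-type nitrogen. In this assay, isobutyl in place of 1,2,2-trimethylpropyl gives a number 7.8 percentage points lower from compound 2 to compound 3 (within the scatter), so the two compounds are read as the same. At this position, the maximal response therefore tolerates going from 6 to 4 heavy atoms and losing the defined stereocentre, at least for this one pair. The data offer no explanation for the size of this step.

From the compounds shown here alone, the pair changes chain size and stereocentre together, so the contribution of each remains open. Also open, going by these compounds, is how the maximal response would read with a cyclohexyl ring or a chain ending in a primary amine on this nitrogen.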